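Acetylpiperazine gives way to acetylpiperidine on a shared core

The source may report more compounds than this note shows. Statements on the series, on what has been measured and on what is new or still open speak of the compounds shown alone.

Of the compounds shown here, three built on one core have been measured in an assay on cells for inhibition of cytochrome P450 11B2, mitochondrial (Homo sapiens), read by HTRF; a higher number here means a weaker inhibitor, a lower number a stronger inhibitor. Compound 1 `CC1(C)c2cc(Cl)ccc2C(=O)N1c1cncc(N2CCN(S(C)(=O)=O)CC2)c1` gives 2 nM, compound 2 `Cc1cccnc1C(=O)NCc1cncc(N2C(=O)c3ccc(Cl)cc3C2(C)C)c1` gives 9 nM, and compound 3 `CC(=O)N1CCN(c2cncc(N3C(=O)c4ccc(Cl)cc4C3(C)C)c2)CC1` gives 9 nM. Compound 3 therefore stands level with compound 2 at the digits shown, the two of them together carrying the highest numbers of the three, and compound 1 lies well below it. For the measured compounds named here, the single one-point step among the measured compounds is a 4.5-fold higher number from compound 1 to compound 3 (0.65 log units; beyond the scatter), an acetyl in place of a methylsulfonyl on an amine nitrogen in a ring.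

Compound 4 `CC(=O)N1CCC(c2cncc(N3C(=O)c4ccc(Cl)cc4C3(C)C)c2)CC1` has not yet been measured. It differs from compound 3 by 1-acetylpiperidin-4-yl in place of 4-acetylpiperazin-1-yl on an aromatic carbon. Going by the values given here, none of the measured steps bears on this kind of change: the one recorded step swaps the group on the ring nitrogen and leaves the ring itself as it was, so it offers no direct guide. Compound 4 is accordingly expected to land close to compound 3. The expected step is a 1.7-fold higher number from compound 3 to compound 4 (0.22 log units; within the scatter), within the scatter or only modestly beyond it. The estimate for compound 4 in this assay is 15 nM, with a range from 5 nM to 50 nM.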

Compound 4, half-maximal inhibitory concentration: 5 nM
Estimate against measurement, compound 4: 3.0-fold (0.48 log units) above, and the stated range covers the measured number.
By their numbers in this assay, from the lowest: compound 1; then compounds 4, 2 and 3 (each within the scatter of the next).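

In this assay, 1-acetylpiperidin-4-yl in place of 4-acetylpiperazin-1-yl, on an aromatic carbon two atoms from the ring nitrogen, gives a 1.8-fold lower number from compound 3 to compound 4 (0.26 log units; within the scatter) and so leaves the two groups indistinguishable at this position. The earlier step had altered only the group on the nitrogen of the non-aromatic ring, whereas this one alters the ring itself, from a six-membered ring with 2 hetero atoms to one with 1 hetero atom and from 2 hydrogen-bond acceptors to 1, while the acetyl stays in place. The result therefore shows that this change to the ring, unlike the earlier exchange on its nitrogen, does not move the number beyond the scatter, and nothing measured here offers an explanation for that.

Going by these compounds, it remains open whether methylsulfonyl on the piperidine nitrogen would reproduce the difference seen on the piperazine, a 4.5-fold higher number from compound 1 to compound 3 (0.65 log units; beyond the scatter), or whether that difference belongs to the piperazine alone. The compounds shown also leave open how this position would respond to a free amine on the ring in place of the acetyl, or to a carboxylic acid at the end of an open chain in place of the ring.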